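Replacing a Benzyl Group with Isopropyl on the Amine

The compounds below may be only part of what the source reports. "The series", "measured", "known", "first", "only" and "open" are said of these compounds alone.

In a functional assay on L02 cells (Homo sapiens) for inhibition, read by Griess assay, with stated times of 1 h and 24 h (on this read-out higher numbers stand for weaker inhibition and lower numbers for stronger inhibition), compound 1 `COc1cc(/C=C/c2nc(Nc3ccc(C(C)C)cc3)c3sccc3n2)cc(OC)c1OC` gives 370000 nM. Compound 2 `COc1cc(/C=C/c2nc(NCc3ccc(C)cc3)c3sccc3n2)cc(OC)c1OC` reaches only the limit of the assay, > 1000000 nM. That limit of > 1000000 nM in this assay, at which 1 of the 2 values shown sits, is all that is known of compound 2, which thus stands at the weak end of the two numbers. Compound 3 `COc1cc(/C=C/c2nc(NC(C)C)c3sccc3n2)cc(OC)c1OC` differs from compound 2 by isopropyl in place of 4-methylbenzyl on a nitrogen on an aromatic ring. Going by the values given here, the only measured step at this nitrogen, an at least 2.7-fold higher number from compound 1 to compound 2 (0.43 log units; beyond the scatter), weakened inhibition, so no recovery is expected. The expected step of a number no higher from compound 2 to compound 3 (the limit leaves the size open) is therefore none beyond the scatter. Compound 3 is estimated at 1000000 nM, within 300000 nM to 3000000 nM.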

Compound 3, half-maximal inhibitory concentration: > 1000000 nM
Compound 3: a limit, no number; the forecaster's own chance of this, stated with the estimate: 60%; the middle value sits exactly at the limit.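

In this assay compound 3 also gives only a limit and not a number, so the step from compound 2 cannot be read. Putting isopropyl in place of 4-isopropylphenyl on this nitrogen gives an at least 2.7-fold higher number from compound 1 to compound 3 (0.43 log units; beyond the scatter) and so weaker inhibition, and isopropyl, with no ring, does not bring back what was lost with 4-methylbenzyl. Of the three groups shown here, only 4-isopropylphenyl gives a measured number. Open, going by these compounds, is whether plain phenyl on this nitrogen would also give a number, and whether an amine or a carboxylic acid in place of the isopropyl of 4-isopropylphenyl would change it.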